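The compounds below may be only part of what the source reports. "The series", "measured", "known", "first", "only" and "open" are said of these compounds alone.

Compound 1 `O=C(O)[C@@H]1CCCN1C(=O)/C=C/c1ccncc1-c1ccc2ccccc2c1` has the lowest number of the three measured compounds in an assay on a protein complex for inhibition of CDK8/Cyclin C (Homo sapiens), with a stated time of 1 h, tested at 10 uM (a higher number here means more inhibition at the concentration tested (going by the name of the read-out), a lower number less inhibition), where compound 1 gives 67%. Its nearest neighbour by number is compound 2 `NC(=O)/C=C/c1ccncc1Nc1ccc(F)cc1`, which in this assay gives 70%, a figure that lies within the usual scatter of compound 1, so no order between the two can be claimed. Compound 3 `Cn1ccc2cc(-c3cnccc3/C=C/C(=O)N3CCOCC3)ccc21` stands further away: in this assay compound 3 gives 97%, a gap to compound 1 that is beyond the scatter.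

The step considered here leads from compound 1 to compound 4 `CN(C)C(=O)/C=C/c1ccncc1-c1ccc2ccccc2c1`. The change is dimethylamino in place of 2-carboxypyrrolidin-1-yl on a carbonyl carbon. Among the measured compounds shown here, no measured pair shows this change, so its effect has to be estimated from what the three compounds show. Compound 3, with its amide and 97%, shows that the shared core can give a high number in this assay, while compound 1 with 67% sits at the bottom. Compound 4 is therefore expected to move upward, though by a step that may not clear the scatter: the estimated step from compound 1 to compound 4 is a number 13 percentage points higher from compound 1 to compound 4 (beyond the scatter). For compound 4 the estimate in this assay is 80%, with a range from 62% to 95%.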

Compound 4, a percentage reported as inhibition, at one concentration (the size of the read-out at that concentration, not a potency): 100%
The estimate for compound 4 lay 20 percentage points below the measured number; measured number above the stated range.
By their numbers in this assay, from the lowest: compounds 1 and 2 (each within the scatter of the next); then compounds 3 and 4 (each within the scatter of the next).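

In this assay, the pair of compound 1 and compound 4 keeps the rest of the structure fixed and shows that the group on this carbonyl carbon can by itself shift the read-out: dimethylamino in place of 2-carboxypyrrolidin-1-yl gives a number 33 percentage points higher from compound 1 to compound 4 (beyond the scatter), a large step. The change is not a single feature, as the group that leaves has 8 heavy atoms, a five-membered non-aromatic ring, a hydrogen-bond donor and a defined stereocentre, while the group that enters has 3 heavy atoms, no ring and no hydrogen-bond donor, and this one pair cannot separate these differences. Nothing at hand explains the step or ties it to any one of them.

Going by these compounds, it remains open whether the step follows the carboxylic acid, the ring or the size of the group, and pyrrolidin-1-yl without the carboxylic acid, or diethylamino on the same carbonyl carbon, would begin to separate these. The read-out also comes from one concentration, and compound 4 gives 100%, so this pair says nothing about any difference in potency beyond that figure.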